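Same carbonyl substituent change on a second core

The compounds below may be only part of what the source reports. "The series", "measured", "known", "first", "only" and "open" are said of these compounds alone.

Compound 1 `CCOC(=O)c1sc2ccc(NCc3c[nH]cn3)cc2c1NC(=O)c1ccc(C)cc1` gives 11700 nM in a functional assay on HeLa cells (Homo sapiens) for antiproliferative activity, read by MTT assay, with a stated time of 48 h; a higher number here means a weaker inhibitor of growth, a lower number a stronger inhibitor of growth. Compound 2 `CCOC(=O)c1sc2ccc(NCc3c[nH]cn3)cc2c1NC(=O)c1ccc(F)c(Cl)c1` gives 10700 nM. The difference between them is 3-chloro-4-fluorophenyl in place of 4-methylphenyl on a carbonyl carbon, and it made a 1.1-fold lower number from compound 1 to compound 2 (0.04 log units; within the scatter). Compound 3 `CCOC(=O)c1sc2ccc(N)cc2c1NC(=O)c1ccc(C)cc1` gives 24400 nM and stands highest of the three measured numbers; its core differs from that of compound 1 by hydrogen in place of (1H-imidazol-4-yl)methyl on a nitrogen on an aromatic ring, a change that gave a 2.1-fold higher number from compound 1 to compound 3 (0.32 log units; beyond the scatter). Compound 4 `CCOC(=O)c1sc2ccc(N)cc2c1NC(=O)c1ccc(F)c(Cl)c1` is not yet measured; it differs from compound 3 by 3-chloro-4-fluorophenyl in place of 4-methylphenyl on a carbonyl carbon, and the place is described in the same words as for the pair of compound 1 and compound 2, so this is the same change on the other core. Compound 3 to compound 4 is expected to show a 1.1-fold lower number from compound 3 to compound 4 (0.04 log units; within the scatter), because the same change gave a 1.1-fold lower number from compound 1 to compound 2 (0.04 log units; within the scatter). Compound 4 is therefore estimated at 22000 nM, expected between 12000 nM and 45000 nM.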

Compound 4, concentration for 50% growth inhibition: 12300 nM
For compound 4 the middle estimate is 1.8-fold (0.25 log units) above the measured one; the range from low to high includes it.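

In this assay, 3-chloro-4-fluorophenyl in place of 4-methylphenyl on the carbonyl carbon gives a 2.0-fold lower number from compound 3 to compound 4 (0.30 log units; within the scatter), and the two cores do not separate on this change: the same change on two cores in this assay, a 1.1-fold lower number (0.04 log units; within the scatter) from compound 1 to compound 2 and a 2.0-fold lower number (0.30 log units; within the scatter) from compound 3 to compound 4, 1.8-fold (0.26 log units) apart, within the scatter of two such steps

Hydrogen in place of (1H-imidazol-4-yl)methyl on the nitrogen on the aromatic ring gives a 1.1-fold higher number from compound 2 to compound 4 (0.06 log units; within the scatter), and this change likewise does not separate the two cores: the same change on two cores in this assay, a 2.1-fold higher number (0.32 log units; beyond the scatter) from compound 1 to compound 3 and a 1.1-fold higher number (0.06 log units; within the scatter) from compound 2 to compound 4, 1.8-fold (0.26 log units) apart, within the scatter of two such steps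

Both changes are therefore consistent with carrying over between these cores, but this rests on just two pairs per change, and it does not show that either change would carry over to any other core.

Still open, going by these compounds, is how a carboxylic acid in place of the ethyl ester would read in this assay. On these data alone, a longer alkyl chain on the nitrogen on the aromatic ring is equally open.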